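Methyl in Place of Chloro: Expected Cytotoxicity Outcome

The source may hold more compounds than are shown below. What is called first, only, known or untested is meant among the compounds shown, and "the series" means these compounds.

Compound 1 `CC[C@@H](CCn1cncn1)c1ccccc1` gives 89.9 ug/mL in an ADME assay on HEp-2 cells (Homo sapiens) for cytotoxicity, read by MTT assay, with a stated time of 3 days; on this read-out higher numbers stand for lower toxicity in this test and lower numbers for higher toxicity in this test.
Compound 2 `CC[C@@H](CCn1cncn1)c1ccc(Cl)cc1` gives 55.1 ug/mL in this assay.

Compound 2 has only compound 1 beside it, and the two values lie within the scatter of each other. Compound 3 `CC[C@@H](CCn1cncn1)c1ccc(C)cc1` differs from compound 2 by methyl in place of chloro on an aromatic carbon. Going by the values given here, the one measured step, a 1.6-fold lower number from compound 1 to compound 2 (0.21 log units; within the scatter), concerns chloro against hydrogen and stayed within the scatter; no measured step involves methyl. A step no larger than the scatter is therefore expected in this assay, namely a 1.2-fold higher number from compound 2 to compound 3 (0.07 log units; within the scatter). Compound 3 is estimated at 65 ug/mL, within 30 ug/mL to 140 ug/mL.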

Compound 3, half-maximal cytotoxic concentration: 69.9 ug/mL
Compound 3: middle estimate off by 1.1-fold (0.03 log units), on the low side, within the range that was stated.
By their numbers in this assay, from the lowest: compounds 2, 3 and 1 (each within the scatter of the next).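

Methyl in place of chloro gives a 1.3-fold higher number from compound 2 to compound 3 (0.10 log units; within the scatter), and methyl in place of hydrogen gives a 1.3-fold lower number from compound 1 to compound 3 (0.11 log units; within the scatter), both in this assay. Two different groups on this aromatic carbon, chloro and methyl, have now been compared with hydrogen, and neither step goes beyond the scatter. No measured evidence here bears on the cause of this result.

The compounds shown leave open whether an amine, a carboxylic acid or a longer chain at this position would give a step beyond the scatter. They also leave open whether changes elsewhere on the shared core would do so.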